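The source may report more compounds than this note shows. Statements on the series, on what has been measured and on what is new or still open speak of the compounds shown alone.

Compound 2 `O=C(CNc1ccc(F)cc1)N[C@H]1CCOC1=O` carries a fluoro group on its aromatic ring. In a functional assay on MCF7 cells (Homo sapiens) for antiproliferative activity, read by MTT assay, with a stated time of 72 h (on this read-out lower numbers stand for stronger inhibition and higher numbers for weaker inhibition), compound 2 gives only a limit, > 64000 nM. Compound 1 `O=C(CNc1ccc(Br)cc1)N[C@H]1CCOC1=O`, with bromo in that position, likewise gives only a limit in this assay, namely > 64000 nM. The step between them is a step that the two limits leave unreadable from compound 1 to compound 2, because of the limit of > 64000 nM in this assay, at which 2 of the 2 values shown sit. Compound 3 `O=C(CNc1ccc(Cl)cc1)N[C@H]1CCOC1=O` differs from compound 2 by chloro in place of fluoro on an aromatic carbon. With both measured compounds sitting at the limit, this swap offers no readable guide, so compound 3 is expected to stay at the limit too, estimated at 100000 nM (range 40000 nM to 300000 nM), an expected step that the limit leaves unreadable from compound 2 to compound 3.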

Compound 3, half-maximal inhibitory concentration: > 64000 nM
Compound 3: no number, only a limit; the forecaster's own chance of this, stated with the estimate: 85%; the middle value lies beyond the limit too.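

No step can be read among compound 1, compound 2 and compound 3, since each gives only a limit and not a number: the limit of > 64000 nM in this assay, at which 3 of the 3 values shown sit. The compounds shown leave open how bromo, fluoro and chloro truly compare.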